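The source may hold more compounds than are shown below. What is called first, only, known or untested is meant among the compounds shown, and "the series" means these compounds.

Compound 1 `C=C1C[C@@H](OC(=O)C2=C(C)OC2)[C@@H](C(C)C)[C@@H]2[C@@H](C(C)=O)[C@@H](OC(=O)/C(C)=C\C)C[C@@H]12` was examined in a functional assay on U-251 cells (Homo sapiens) for cytotoxicity; a higher number here means a weaker inhibitor, a lower number a stronger inhibitor. For compound 1 the assay reports only a limit, > 100000 nM, and no number; that is the limit of > 100000 nM in this assay, at which 1 of the 2 values shown sits. Going by the values given here, compound 2 `C/C=C(/C)C(=O)O[C@H]1C[C@@H](O)C2=CC(=O)C(=C(C)C)C[C@]2(C)[C@H]1C` is the one compound with a measured number, giving 24100 nM in this assay. Compound 3 `C/C=C(/C)C(=O)O[C@H]1C[C@@H](OC(=O)/C(C)=C/C)C2=CC(=O)C(=C(C)C)C[C@]2(C)[C@H]1C` differs from compound 2 in one place: (1-methylprop-1-en-1-yl)carbonyl in place of hydrogen on an oxygen on a saturated carbon. Among the compounds with values here, no measured pair shows this change, so its direction is unknown; only a small step, close to the scatter, is expected, and a 1.6-fold lower number from compound 2 to compound 3 (0.21 log units; within the scatter) is the expected size. Compound 3 is therefore estimated at 15000 nM, with a range from 4000 nM to 60000 nM.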

Compound 3, half-maximal inhibitory concentration: 17600 nM
The estimate for compound 3 lay 1.2-fold (0.07 log units) below the measured number; low and high end bracket the measured number.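

In this assay, ((1-methylprop-1-en-1-yl)carbonyl)oxy in place of hydroxy on this saturated carbon gives a 1.4-fold lower number from compound 2 to compound 3 (0.14 log units; within the scatter). Going by these compounds alone, this is the first reading at this position, and it shows that the hydrogen on this oxygen can be replaced by this group with no change beyond the scatter. Nothing measured here offers a reason for this result. The compounds shown leave open whether an acetyl group, a longer acyl chain or an amine at this position would also leave the value in this assay unchanged.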